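Swapping the benzyl ether aryl group in a Mahlavu antiproliferative series

The source may report more compounds than this note shows. Statements on the series, on what has been measured and on what is new or still open speak of the compounds shown alone.

Measured compounds:
Compound 1, `Cc1cccc(COc2ccc(-c3cc(CN4CCN(Cc5ccc(C(F)(F)F)cc5)CC4)no3)cc2)c1`: 2500 nM
Compound 2, `N#Cc1ccc(COc2ccc(-c3cc(CN4CCN(Cc5ccc(C(F)(F)F)cc5)CC4)no3)cc2)cc1`: 4300 nM

In a functional assay on Mahlavu cells (Homo sapiens) for antiproliferative activity, read by sulforhodamine B assay, with a stated time of 72 h (on this read-out higher numbers stand for weaker inhibition and lower numbers for stronger inhibition), compound 1 gives 2500 nM, and compound 2 gives 4300 nM. These two values sit close together: the step of a 1.7-fold higher number from compound 1 to compound 2 (0.24 log units; within the scatter) does not exceed the usual spread of repeated measurements, so the two cannot be told apart on this read-out.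

Compound 3, `COc1ccc(COc2ccc(-c3cc(CN4CCN(Cc5ccc(C(F)(F)F)cc5)CC4)no3)cc2)cc1`, has not yet been measured. It differs from compound 1 by a single exchange, (4-methoxyphenyl in place of 3-methylphenyl on a saturated chain carbon bound to an oxygen on an aromatic ring). Within the data shown here, the only measured step that bears on this position is the one from compound 1 to compound 2, in which 4-cyanophenyl replaced 3-methylphenyl at the same place and the number barely moved. Among the measured compounds shown here, that is the whole basis available here; no step with a methoxy group has been measured.

Compound 3 is therefore expected to land close to compound 1, with a step of a 1.2-fold higher number from compound 1 to compound 3 (0.08 log units; within the scatter) in this assay, which amounts to no change beyond the scatter. The estimated value for compound 3 in this assay is 3000 nM, with a likely range from 1200 nM to 7500 nM.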

Compound 3, half-maximal inhibitory concentration: 4900 nM
The estimate for compound 3 lay 1.6-fold (0.21 log units) below the measured number; the measured number falls inside the stated range.
By their numbers in this assay, from the lowest: compounds 1, 2 and 3 (each within the scatter of the next).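

In this assay the exchange of 3-methylphenyl for 4-methoxyphenyl gives a 2.0-fold higher number from compound 1 to compound 3 (0.29 log units; within the scatter) and stays within the scatter, and the exchange of cyano for methoxy on an aromatic carbon gives a 1.1-fold higher number from compound 2 to compound 3 (0.06 log units; within the scatter) and does so too. Compounds 1, 2 and 3 thus carry three different substituted phenyl groups on the saturated chain carbon bound to an oxygen on an aromatic ring, yet their numbers cannot be told apart, so this small set shows no preference among methyl, cyano and methoxy at this place. No measurement at hand offers a reason for this flat result.

The step between compound 1 and compound 3 changes both the substituent and its ring position, so a 4-methylphenyl or 3-methoxyphenyl group would be needed to separate those two changes. On these data alone, it also remains open whether the same flat picture would hold for an unsubstituted phenyl group, for a ring carrying an amine or a carboxylic acid, or for a longer chain between the oxygen and the ring.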